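Swapping in an amino group on compound 3

The compounds below may be only part of what the source reports. "The series", "measured", "known", "first", "only" and "open" are said of these compounds alone.

- compound 1 `COc1cc(-n2cnc3ccc(-c4ccc(C(C)=O)cc4)cc32)cc(OC)c1OC` gives 2510 nM
- compound 2 `COc1cc(-n2cnc3ccc(-c4cc(F)ccc4F)cc32)cc(OC)c1OC` gives 7940 nM
- compound 3 `COc1cc(-n2cnc3ccc(-c4cccc(C)c4C)cc32)cc(OC)c1OC` gives 9250 nM

In a functional assay on A549 cells (Homo sapiens) for antiproliferative activity, read by MTT assay, with a stated time of 72 h (a higher number here means a weaker inhibitor, a lower number a stronger inhibitor), compound 3 cannot be told apart from compound 2, since the data show a 1.2-fold higher number from compound 2 to compound 3 (0.07 log units; within the scatter). Compound 1 does stand apart, with a 3.7-fold higher number from compound 1 to compound 3 (0.57 log units; beyond the scatter) and a 3.2-fold higher number from compound 1 to compound 2 (0.50 log units; beyond the scatter).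

These three compounds differ only in one group on the shared core. Compound 4 `COc1cc(-n2cnc3ccc(-c4cccc(N)c4)cc32)cc(OC)c1OC` changes that same place, with 3-aminophenyl in place of 2,3-dimethylphenyl on an aromatic carbon. For the measured compounds named here, no measured compound carries an amino group, so direct evidence is missing. The measured swaps at this place were modest or lay within the scatter, which argues against a large jump. Compound 3 at 9250 nM already lies at the weak end of this small set, so a fall looks likelier than a further rise. The expected change in this assay is a 2.6-fold lower number from compound 3 to compound 4 (0.42 log units; beyond the scatter), a modest step towards a stronger inhibitor. For compound 4 the estimated value is 3500 nM, with an expected range from 1100 nM to 10000 nM.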

Compound 4, half-maximal inhibitory concentration: 640 nM
Compound 4: the middle estimate sits 5.5-fold (0.74 log units) above what was measured, outside the stated range (below it).
By their numbers in this assay, from the lowest: compound 4; then compound 1; then compounds 2 and 3 (each within the scatter of the next).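

In this assay, for the compounds shown here, this position proves far more sensitive than the earlier compounds suggested: 3-aminophenyl gives a 14-fold lower number from compound 3 to compound 4 (1.16 log units; beyond the scatter) and a 12-fold lower number from compound 2 to compound 4 (1.09 log units; beyond the scatter), both large steps, whereas the earlier swaps were modest or lay within the scatter. Even 4-acetylphenyl, the group with the lowest number among the earlier compounds, falls behind, with a 3.9-fold lower number from compound 1 to compound 4 (0.59 log units; beyond the scatter), so a single amino-bearing ring sets compound 4 apart from all three others. Nothing available here explains this gain.

The compounds shown cannot separate the contribution of the amino group from that of its place on the ring. An unsubstituted phenyl, a 4-aminophenyl and a 3-hydroxyphenyl group at this position would each help to settle that question, and a longer chain carrying the amine remains an open option too.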